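Lengthening the Amide Substituent from Compound 3 to Compound 4

A few compounds are considered here, and "the series" means these few. Any claim that something is new, unique, unknown or untested is made for them only; others in the source may bear on it.

Of the compounds shown here, three with a shared core have been tested in a functional assay on MCF7 cells (Homo sapiens) for inhibition, read by MTT assay, with a stated time of 48 h; a lower number here means a stronger inhibitor, a higher number a weaker inhibitor. Compound 1 `COc1ccc(/C=C/c2cc(OC)cc(OC)c2/C=C/C(=O)Nc2cc(OC)c(OC)c(OC)c2)cc1` gives 7010 nM, compound 2 `COc1ccc(/C=C/c2cc(OC)cc(OC)c2/C=C/C(=O)N2CCC(c3ccccc3)CC2)cc1` gives 4230 nM, and compound 3 `CCNC(=O)/C=C/c1c(/C=C/c2ccc(OC)cc2)cc(OC)cc1OC` gives 7060 nM. Compound 3 carries the highest of the three numbers, yet its differences from compound 1 and from compound 2 both fall within the scatter, so the three compounds cannot be told apart.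

Compound 4 `CCCCCCNC(=O)/C=C/c1c(/C=C/c2ccc(OC)cc2)cc(OC)cc1OC` differs from compound 3 in one place: butyl in place of hydrogen on a saturated chain carbon, two bonds along the chain from an amide-type nitrogen. Within the data shown here, two measured steps bear on this, since both alter the group attached through the amide: a 1.0-fold higher number from compound 1 to compound 3 (0.00 log units; within the scatter) and a 1.7-fold higher number from compound 2 to compound 3 (0.22 log units; within the scatter). A 3,4,5-trimethoxyphenyl group and a 4-phenylpiperidin-1-yl group each gave a number indistinguishable from the ethylamino of compound 3. Going from ethylamino to hexylamino is therefore expected to leave the number where it is, with the step of a 1.2-fold lower number from compound 3 to compound 4 (0.07 log units; within the scatter) expected to stay within the scatter. Compound 4 is estimated at 6000 nM, with a range from 2500 nM to 15000 nM.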

Compound 4, half-maximal inhibitory concentration: 5530 nM
Compound 4: the middle estimate sits 1.1-fold (0.04 log units) above what was measured, within the range that was stated.
By their numbers in this assay, from the lowest: compounds 2, 4, 1 and 3 (each within the scatter of the next).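

In this assay, butyl in place of hydrogen on this saturated chain carbon, which turns ethylamino into hexylamino, gives a 1.3-fold lower number from compound 3 to compound 4 (0.11 log units; within the scatter) and so leaves no readable effect at this position. The earlier compounds shown here had compared the ethyl of compound 3 only with groups containing rings; the new steps add a longer open chain to that comparison. Hexyl stands level with 3,4,5-trimethoxyphenyl, with a 1.3-fold lower number from compound 1 to compound 4 (0.10 log units; within the scatter) on that swap, and hexylamino stands level with 4-phenylpiperidin-1-yl, with a 1.3-fold higher number from compound 2 to compound 4 (0.12 log units; within the scatter) on that swap, so all four groups remain indistinguishable here. As far as these compounds go, whether a chain longer than hexyl, or an amine or a carboxylic acid in its place, would move the number beyond the scatter stays open. Nothing available explains why these groups give such similar numbers.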